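Chromene series: aryl swap on the isoxazole, MTT readout

The compounds below may be only part of what the source reports. "The series", "measured", "known", "first", "only" and "open" are said of these compounds alone.

Measured so far:
compound 1 `CCOC(=O)C1=Cc2ccccc2OC1(OCc1cc(-c2ccc(F)cc2F)no1)C(F)(F)F` — > 150000 nM
compound 2 `CCOC(=O)C1=Cc2ccccc2OC1(OCc1cn(-c2cccc(OC)c2)nn1)C(F)(F)F` — > 150000 nM
compound 3 `CCCCCCCCn1cc(COC2(C(F)(F)F)Oc3ccccc3C=C2C(=O)OCC)nn1` — > 150000 nM

In a functional assay on MCF7 cells (Homo sapiens) for inhibition, read by MTT assay, with a stated time of 24 h (a lower number here means a stronger inhibitor, a higher number a weaker inhibitor), compound 1 gives > 150000 nM, which is a limit of the assay, not a number. Compound 2 likewise sits at a limit, > 150000 nM. Compound 3 also gives only a limit, > 150000 nM. Going by the values given here, the one step between two compounds differing in one place, a step that the two limits leave unreadable from compound 2 to compound 3, is therefore unreadable. All three values rest on (the limit of > 150000 nM in this assay, at which 3 of the 3 values shown sit).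

Compound 4 `CCOC(=O)C1=Cc2ccccc2OC1(OCc1cc(-c2ccc(Cl)cc2)no1)C(F)(F)F` differs from compound 1 by 4-chlorophenyl in place of 2,4-difluorophenyl on an aromatic carbon. No measured step bears on this change; nothing shown separates any compound from the limit. Compound 4 is expected at 200000 nM, within 100000 nM to 500000 nM. The expected step, a step that the limit leaves unreadable from compound 1 to compound 4, is none beyond the scatter, most likely another limit.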

Compound 4, half-maximal inhibitory concentration: 18200 nM
Compound 4: middle estimate off by 11-fold (1.04 log units), on the high side; the whole stated range lies above it.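

In this assay, 4-chlorophenyl in place of 2,4-difluorophenyl gives an at least 8.2-fold lower number from compound 1 to compound 4 (0.91 log units; beyond the scatter). The aromatic carbon next to the ring nitrogen therefore responds to the aryl group it carries, and compound 4 is the first compound shown with a readable number rather than a limit. The true size of the step stays unknown, since compound 1 gives only a limit: the limit of > 150000 nM in this assay, at which 3 of the 4 values shown sit.

The compounds shown leave open whether the chlorine or the loss of the two fluorines carries the step. As far as these compounds go, how a plain phenyl, a 4-bromophenyl or an aryl ring bearing an amine would read also remains open.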